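The source may report more compounds than this note shows. Statements on the series, on what has been measured and on what is new or still open speak of the compounds shown alone.

Measured so far:
compound 1 `COc1cc2c(cc1OC)C(=O)/C(=C/c1cccc(C)c1)CC2` — 17000 nM
compound 2 `COc1cc2c(cc1OC)C(=O)/C(=C/c1ccc(O)cc1)CC2` — 19000 nM

Going by the values given here, in a functional assay on Jurkat cells (Homo sapiens) for antiproliferative activity, read by MTT assay (a higher number here means a weaker inhibitor, a lower number a stronger inhibitor), compound 2 gives 19000 nM and compound 1 gives 17000 nM; the two sit within the scatter of one another, the only measured step being a 1.1-fold higher number from compound 1 to compound 2 (0.05 log units; within the scatter).

Compound 3 `COc1cc2c(cc1OC)C(=O)/C(=C/c1cc(C)ccc1C)CC2` is not yet measured. It differs from compound 2 by 2,5-dimethylphenyl in place of 4-hydroxyphenyl on a double-bonded chain carbon bound to a double-bonded ring carbon. Among the compounds with values here, no measured step covers this exact exchange. Within the data shown here, the one step that bears on it, a 1.1-fold higher number from compound 1 to compound 2 (0.05 log units; within the scatter), shows that swapping a methyl-bearing phenyl for the 4-hydroxyphenyl left this assay unchanged beyond the scatter. Returning to a methyl-bearing phenyl, now with two methyl groups, is therefore expected to give no step beyond the scatter, if anything a slightly lower number in the direction of compound 1 with its 17000 nM.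

Compound 3 is estimated at 15000 nM, with a range from 6000 nM to 40000 nM. That estimate means an expected 1.3-fold lower number from compound 2 to compound 3 (0.10 log units; within the scatter).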

Compound 3, half-maximal inhibitory concentration: 6000 nM
Beside the measured number, compound 3's estimate is 2.5-fold (0.40 log units) above it; the measured number falls inside the stated range.
By their numbers in this assay, from the lowest: compound 3; then compounds 1 and 2 (each within the scatter of the next).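

In this assay, the position on the double-bonded chain carbon bound to a double-bonded ring carbon now responds beyond the scatter: 2,5-dimethylphenyl in place of 4-hydroxyphenyl gives a 3.2-fold lower number from compound 2 to compound 3 (0.50 log units; beyond the scatter), whereas the earlier exchange gave only a 1.1-fold higher number from compound 1 to compound 2 (0.05 log units; within the scatter). The smaller change, methyl in place of hydrogen on an aromatic carbon, gives a 2.8-fold lower number from compound 1 to compound 3 (0.45 log units; beyond the scatter), so one added methyl is enough to separate compound 3 from compound 1, and compound 3 is the strongest of the three. Nothing at hand explains these steps.

Going by these compounds, whether the lower number is specific to methyl, or would also follow with chloro, methoxy or an amine on the phenyl, stays open. So does whether a longer chain such as ethyl would extend the step.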